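From compound 2 to compound 4: adding a carboxy group

The source may hold more compounds than are shown below. What is called first, only, known or untested is meant among the compounds shown, and "the series" means these compounds.

For the measured compounds named here, in an ADME assay on microsomes from liver (Rattus norvegicus) for metabolic stability, read by LC-MS, with a stated time of 1 h, at 37 degrees C, tested at 4 uM (on this read-out higher numbers stand for a more stable compound and lower numbers for a less stable compound), compound 2 `O=C1c2ccc(OCc3cccc(-c4ccccc4)c3)cc2CN1C1CCCC1` gives 38%, the lowest number so far. Compound 1 `O=C(O)c1cc(-c2cccc(COc3ccc4c(=O)n(CC5CC5)sc4c3)c2)ccc1Cl` gives 75% and compound 3 `O=C(O)c1cc(-c2cccc(COc3ccc4c(=O)n(C5CCC5)sc4c3)c2)ccc1Cl` gives 67%, and both carry a carboxy group on a different core. Compound 4 `O=C(O)c1cc(F)cc(-c2cccc(COc3ccc4c(c3)CN(C3CCCC3)C4=O)c2)c1` keeps the core of compound 2 but has 3-carboxy-5-fluorophenyl in place of phenyl on an aromatic carbon. Going by the values given here, the only measured step, a number 8 percentage points lower from compound 1 to compound 3 (within the scatter), concerns a group on an aromatic nitrogen, so no measured step covers this change. A rise is expected from the standing of compound 3 at 67%, with wide uncertainty since the cores differ. The expected change is a number 27 percentage points higher from compound 2 to compound 4 (beyond the scatter). Compound 4 is estimated at 65%, within a range from 45% to 85%.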

Compound 4, percent of the compound remaining: 55%
Estimate against measurement, compound 4: 10 percentage points above, and the stated range covers the measured number.
By their numbers in this assay, from the lowest: compound 2; then compound 4; then compounds 3 and 1 (each within the scatter of the next).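

In this assay on the core of compound 2, 3-carboxy-5-fluorophenyl in place of phenyl on an aromatic carbon gives a number 17 percentage points higher from compound 2 to compound 4 (beyond the scatter) for this change. For the compounds shown here, this is the first measured sign that this position affects the read-out, as the only earlier step concerned a group on an aromatic nitrogen. No measured evidence explains the rise. The carboxy group and the fluorine enter together, and which of them accounts for the step stays open. Also open, on these data alone, is how a plain 3-carboxyphenyl, or a phenyl bearing an amine, would read at this position.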